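The source may report more compounds than this note shows. Statements on the series, on what has been measured and on what is new or still open speak of the compounds shown alone.

Working notes on the series. Compound 1 `CCOc1ccc2sc(S(C)(=O)=O)nc2c1S(=O)(=O)NC(C)(C)C` gives 76600 nM in a functional assay on HeLa cells (Homo sapiens) for inhibition, read by sulforhodamine B assay, with a stated time of 48 h; on this read-out higher numbers stand for lower toxicity in this test and lower numbers for higher toxicity in this test. On the numbers shown it holds the smallest value of the three, but neither neighbour stands apart from it: compound 3 `CCOc1ccc2sc(S(C)(=O)=O)nc2c1S(=O)(=O)Nc1ccc([N+](=O)[O-])cc1` gives 81500 nM, and compound 2 `CCOc1ccc2sc(S(C)(=O)=O)nc2c1S(=O)(=O)NC(CC)CC` gives 87400 nM. The steps among them are a 1.1-fold higher number from compound 1 to compound 2 (0.06 log units; within the scatter), a 1.1-fold higher number from compound 1 to compound 3 (0.03 log units; within the scatter) and a 1.1-fold lower number from compound 2 to compound 3 (0.03 log units; within the scatter), each one confined to the group on the sulfonamide nitrogen and each within the scatter.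

Compound 4 `CCOc1ccc2sc(S(C)(=O)=O)nc2c1N` is the next member. Against compound 1 the change is amino in place of (tert-butyl)sulfamoyl on an aromatic carbon. For the measured compounds named here, this removes the whole sulfamoyl group rather than swapping what sits on its nitrogen, so none of the measured steps probes exactly this move; they show only that three different nitrogen substituents left this assay unmoved. Going by these compounds, in that light no step beyond the scatter is expected for compound 4, with the caveat that the removal itself is untested. Compound 4 is estimated at 80000 nM in this assay, with a range from 30000 nM to 200000 nM; the expected step is a 1.0-fold higher number from compound 1 to compound 4 (0.02 log units; within the scatter).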

Compound 4, concentration lethal to 50% of the cells: > 100000 nM
Compound 4: no number, only a limit; the forecaster's own chance of this, stated with the estimate: 25%; at least 1.2-fold (0.09 log units) between middle value and limit.
By their numbers in this assay, from the lowest: compounds 1, 3 and 2 (each within the scatter of the next). At a limit, above all of these: compound 4.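

In this assay compound 4 reads only as a limit, > 100000 nM, and not as a number. The step is an at least 1.3-fold higher number from compound 1 to compound 4 (0.11 log units; that floor lies within the scatter), so the change reaches past the sulfonamide nitrogen substituents varied earlier and takes away the whole (tert-butyl)sulfamoyl group, yet the read-out gives no sign of a lower number and the floor of the step does not by itself separate the pair. At this aromatic carbon the result is therefore bounded on one side only, and the true size of the step cannot be read: the limit of > 100000 nM in this assay, at which 1 of the 4 values shown sits.

For the compounds shown here, whether amino itself or the loss of the sulfamoyl group sets this reading stays open, as no compound carries a different group at this place. A carboxylic acid or an acetamide on the same aromatic carbon would bear on that question, particularly if it gave a number rather than a limit.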